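The compounds below may be only part of what the source reports. "The series", "measured", "known", "first", "only" and "open" are said of these compounds alone.

Measured so far in a functional assay on RPMI-8226 cells (Homo sapiens) for cytotoxicity, read by MTT assay, with a stated time of 72 h; on this read-out lower numbers stand for stronger inhibition and higher numbers for weaker inhibition:
- compound 1 `Cc1c(C)c2c(c(C)c1OC(=O)CCC(=O)O)CCC(C)(C(=O)NC1CC(C)(C)N([O])C(C)(C)C1)O2`: > 300000 nM (a limit of the assay, not a number)
- compound 2 `Cc1c(C)c2c(c(C)c1O)CCC(C)(C(=O)NC1CC(C)(C)N([O])C1(C)C)O2`: 58000 nM

Among the compounds with values here, compound 2, at 58000 nM, holds the only true number so far. Compound 3 `Cc1c(C)c2c(c(C)c1OC(=O)CCC(=O)O)CCC(C)(C(=O)NC1CC(C)(C)N([O])C1(C)C)O2` is still unmeasured in this assay. It derives from compound 2 by placing (2-carboxyethyl)carbonyl in place of hydrogen on an oxygen on an aromatic ring.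

Within the data shown here, no measured step covers this change, so the expectation rests on a single compound. Compound 1 also carries (2-carboxyethyl)carbonyl on an oxygen on an aromatic ring, and its > 300000 nM is a limit only. A step towards weaker inhibition is therefore expected, and the expected size is a 3.4-fold higher number from compound 2 to compound 3 (0.54 log units; beyond the scatter). The result may also come back as a limit only. For compound 3 the estimated value is 200000 nM, with an expected range of 70000 nM to 500000 nM.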

Compound 3, half-maximal inhibitory concentration: > 300000 nM
Compound 3 ended at the assay's limit; the forecaster's own chance of this, stated with the estimate: 50%; middle value at least 1.5-fold (0.17 log units) from the limit.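

In this assay, the change from hydroxy to ((2-carboxyethyl)carbonyl)oxy on an oxygen on an aromatic ring now has a measured step with the amide group held constant: an at least 5.1-fold higher number from compound 2 to compound 3 (0.71 log units; beyond the scatter). Compound 3 gives > 300000 nM, which is a limit of the assay and not a number, so the step has a lower bound and no readable upper end. The step between compound 1 and compound 3 cannot be read, so the change on the amide-type nitrogen remains unresolved, with both compounds resting on the same limit: the limit of > 300000 nM in this assay, at which 2 of the 3 values shown sit.

On these data alone, it remains open whether the weaker inhibition belongs to the (2-carboxyethyl)carbonyl group specifically or to any group on this oxygen, which an acetyl group, a methyl ether or an aminoalkyl chain there could test. As far as these compounds go, the effect of the amide-type nitrogen group also remains open with the hydroxy form, where a measured number could allow a readable comparison.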